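The source may hold more compounds than are shown below. What is called first, only, known or untested is meant among the compounds shown, and "the series" means these compounds.

In a functional assay on HeLa cells (Homo sapiens) for antiproliferative activity, read by spectrophotometry, with a stated time of 2 days (on this read-out higher numbers stand for weaker inhibition of growth and lower numbers for stronger inhibition of growth), compound 1 (`Cc1ccc(Nc2ncc(C(F)(F)F)c(N3Cc4cccc(N(C)S(C)(=O)=O)c4C3)n2)cc1C`) gives > 30000 nM, which is a limit of the assay and not an exact number. For the measured compounds named here, compound 2 (`CN(c1cccc2c1CN(c1nc(Nc3cc(C(F)(F)F)cc(C(F)(F)F)c3)ncc1C(F)(F)F)C2)S(C)(=O)=O`) gives a true number, 9200 nM, so these two values are the only guide here. Compound 3 (`COc1cc(Nc2ncc(C(F)(F)F)c(N3Cc4cccc(N(C)S(C)(=O)=O)c4C3)n2)cc(OC)c1`) keeps the core of compound 1 and has 3,5-dimethoxyphenyl in place of 3,4-dimethylphenyl on a nitrogen on an aromatic ring, a change counted as 3,5-dimethoxyphenyl in place of 3,4-dimethylphenyl on a nitrogen on an aromatic ring. Going by the values given here, no measured step shows what this swap does, so any expectation is loose. The value of compound 2, 9200 nM, suggests that a number within the range of this assay is possible, but only a modest gain in growth inhibition is expected. The estimated step is an at least 1.6-fold lower number from compound 1 to compound 3 (0.22 log units; that floor lies within the scatter). Compound 3 is expected to give about 18000 nM, within an estimated range of 6000 nM to 40000 nM.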

Compound 3, concentration for 50% growth inhibition: 7000 nM
Compound 3: middle estimate off by 2.6-fold (0.41 log units), on the high side; measured number inside the range.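

For the compounds shown here, with the core of compound 1 held fixed, this is the first step showing that the group on this nitrogen can by itself shift the result in this assay: 3,5-dimethoxyphenyl in place of 3,4-dimethylphenyl gives an at least 4.2-fold lower number from compound 1 to compound 3 (0.63 log units; beyond the scatter). The entering group carries oxygen and hydrogen-bond acceptors while the leaving group has only carbon, but this single swap cannot tell which feature of the change is responsible. The full size of the step stays unknown, because compound 1 stands at a limit of the assay: the limit of > 30000 nM in this assay, at which 1 of the 3 values shown sits.

The compounds shown leave open how a plain phenyl, or a phenyl ring carrying an amine or a carboxylic acid, would behave at this position. They also leave open whether the same swap would have a similar effect on a different core.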